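The source may report more compounds than this note shows. Statements on the series, on what has been measured and on what is new or still open speak of the compounds shown alone.

Going by the values given here, compound 1 `CCCN(CCC)c1ccc(NC(=O)c2cc(Cl)ccc2O)c(Cl)c1` gives the higher of the two numbers so far in an ADME assay on A549 cells (Homo sapiens) for cytotoxicity, read by LDH release, with a stated time of 15 h (a lower number here means that less compound is tolerated, a higher number that more compound is tolerated), namely 323000 nM. Compound 2 `CCCC(C)(C)Nc1ccc(NC(=O)c2cc(Cl)ccc2O)c(Cl)c1` gives 23700 nM. Among the compounds with values here, the single measured step, a 14-fold lower number from compound 1 to compound 2 (1.13 log units; beyond the scatter), also replaces the dipropylamino at the same place. Compound 3 `O=C(Nc1ccc(NCc2ccccc2)cc1Cl)c1cc(Cl)ccc1O` differs from compound 1 by benzylamino in place of dipropylamino on an aromatic carbon. Because a 14-fold lower number from compound 1 to compound 2 (1.13 log units; beyond the scatter) concerned the same group, a lower number is expected for compound 3, though the group entering here is a different one and the size of the step is uncertain. The expected step is a 5.4-fold lower number from compound 1 to compound 3 (0.73 log units; beyond the scatter). Compound 3 is estimated at 60000 nM, between 15000 nM and 250000 nM.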

Compound 3, half-maximal cytotoxic concentration: 81300 nM
For compound 3 the middle estimate is 1.4-fold (0.13 log units) below the measured one; the measured number falls inside the stated range.
By their numbers in this assay, from the lowest: compound 2; then compound 3; then compound 1.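

In this assay a second replacement of the dipropylamino on the aromatic carbon also lowers the number, with a 4.0-fold lower number from compound 1 to compound 3 (0.60 log units; beyond the scatter). The entering group matters as well: with benzyl in place of 1,1-dimethylbutyl on the same nitrogen, there is a 3.4-fold higher number from compound 2 to compound 3 (0.54 log units; beyond the scatter), so the size of the drop differs between the two replacements. No data on the compounds shown bear on the reason for these differences. From the compounds shown here alone, whether the number follows the hydrogen on the nitrogen or the carbon group attached to it stays open. A propylamino or a morpholine ring at this place would help separate the two.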